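Amide nitrogen substituent step toward compound 4

A few compounds are considered here, and "the series" means these few. Any claim that something is new, unique, unknown or untested is made for them only; others in the source may bear on it.

Measured in an assay on isolated protein for inhibition of glutathione S-transferase Mu 2 (Homo sapiens), with a stated time of 10 min; a higher number here means a weaker inhibitor, a lower number a stronger inhibitor:
compound 1 `O=C(CCC(=O)OCCCCCCSc1ccc([N+](=O)[O-])c2nonc12)Nc1ccccc1F` gives 350 nM;
compound 2 `O=C(CCC(=O)OCCCCCCSc1ccc([N+](=O)[O-])c2nonc12)Nc1ccc(Br)cc1` gives 32000 nM;
compound 3 `COc1ccc(NC(=O)CCC(=O)OCCCCCCSc2ccc([N+](=O)[O-])c3nonc23)cc1` gives 130 nM.

Compound 3 stands lowest of the three numbers; its nearest neighbour is set by a 2.7-fold lower number from compound 1 to compound 3 (0.43 log units; beyond the scatter), its furthest by a 250-fold lower number from compound 2 to compound 3 (2.39 log units; beyond the scatter). Compound 4 `CN(C)CCCNC(=O)CCC(=O)OCCCCCCSc1ccc([N+](=O)[O-])c2nonc12` differs from compound 3 by 3-(dimethylamino)propyl in place of 4-methoxyphenyl on an amide-type nitrogen. Within the data shown here, the measured steps only exchange one substituted phenyl for another, yet they span modest to large, as in a 91-fold higher number from compound 1 to compound 2 (1.96 log units; beyond the scatter); no measured step removes the ring altogether, so the change to compound 4 has no direct precedent. Given that sensitivity, a step toward a higher number is expected, a 23-fold higher number from compound 3 to compound 4 (1.36 log units; beyond the scatter), with wide uncertainty. Compound 4 is estimated at 3000 nM, in the range 300 nM to 30000 nM.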

Compound 4, half-maximal inhibitory concentration: 90 nM
The estimate for compound 4 lay 33-fold (1.52 log units) above the measured number; the whole stated range lies above it.
By their numbers in this assay, from the lowest: compounds 4 and 3 (each within the scatter of the next); then compound 1; then compound 2.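

On the amide-type nitrogen, an aromatic ring is not needed to hold the number in this assay: the ringless 3-(dimethylamino)propyl group and 4-methoxyphenyl lie within the scatter of each other (a 1.4-fold lower number from compound 3 to compound 4 (0.16 log units; within the scatter)). The same group also stands clear of both halogen-bearing phenyl compounds (a 3.9-fold lower number from compound 1 to compound 4 (0.59 log units; beyond the scatter); a 360-fold lower number from compound 2 to compound 4 (2.55 log units; beyond the scatter)). No available evidence accounts for this tolerance.

Still open, as far as these compounds go, is whether the dimethylamino end matters or the chain alone suffices. A plain butyl chain, a primary amine, a carboxylic acid or a longer chain on this nitrogen would help separate these.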